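The compounds below may be only part of what the source reports. "The series", "measured", "known", "first", "only" and "open" are said of these compounds alone.

Measured in an ADME assay on L02 cells (Homo sapiens) for cytotoxicity, read by MTT assay, with a stated time of 48 h; a higher number here means a weaker inhibitor, a lower number a stronger inhibitor:
Compound 1, `Cc1ccc(Cn2cc(COc3ccc4c(=O)ccoc4c3)nn2)cc1`, gives only a limit of this assay, not a number: > 300000 nM.
Compound 2, `O=c1ccoc2cc(OCc3cn(Cc4cccc([N+](=O)[O-])c4)nn3)ccc12`, gives likewise only a limit: > 300000 nM.
Compound 3, `O=c1ccoc2cc(OCc3cn(Cc4ccccc4Br)nn3)ccc12`, gives likewise only a limit: > 300000 nM.

Compound 1 therefore stands at a limit of this assay and nowhere on a measured scale. Compound 2 and compound 3 sit at the same limit, as the limit of > 300000 nM in this assay, at which 3 of the 3 values shown sit, records. The unmeasured compound 4, `N#Cc1cccc(Cn2cc(COc3ccc4c(=O)ccoc4c3)nn2)c1`, differs from compound 1 by 3-cyanophenyl in place of 4-methylphenyl on a saturated chain carbon bound to an aromatic nitrogen. For the measured compounds named here, the steps that bear on this place are a step that the two limits leave unreadable from compound 1 to compound 2 and a step that the two limits leave unreadable from compound 1 to compound 3, with a step that the two limits leave unreadable from compound 2 to compound 3 between them; none of them has a readable size because each end sits at the limit of > 300000 nM in this assay, at which 3 of the 3 values shown sit. No step beyond the scatter can be read in either direction from these three, so compound 4 is expected to sit at the limit as well rather than at a number. For compound 4 the estimated value in this assay is 400000 nM, with a range from 200000 nM to 1500000 nM. The step this estimate means is a step that the limit leaves unreadable from compound 1 to compound 4, expected to be no step beyond the scatter.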

Compound 4, half-maximal inhibitory concentration: > 300000 nM
Compound 4 gave a limit, no number (the forecaster's own chance of this, stated with the estimate: 85%); the middle value does not contradict the limit.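

No step can be read between compound 4 and compound 1, compound 2 or compound 3, as all four compounds give a limit, not a number: the limit of > 300000 nM in this assay, at which 4 of the 4 values shown sit. The compounds shown leave open how far each lies from that limit, and whether changing the benzyl group shifts the read-out at all.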